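The source may report more compounds than this note shows. Statements on the series, on what has been measured and on what is new or still open speak of the compounds shown alone.

Measured compounds:
compound 1 `CC(Sc1nnc(-c2ccncc2)s1)C(=O)NCc1ccc(Cl)cc1`: "not determined" (no result reported)
compound 2 `O=C(CCSc1nnc(-c2ccncc2)s1)Nc1ccccc1`: > 50000 nM
compound 3 `CC(CSc1nnc(-c2ccncc2)s1)C(=O)Nc1ccccc1Cl`: > 50000 nM

In an ADME assay on HepG2 cells (Homo sapiens) for cytotoxicity, with a stated time of 3 days (a lower number here means that less compound is tolerated, a higher number that more compound is tolerated), compound 1 stands without a number; its entry reads "not determined" (no result reported). Compound 2 gives only a limit of the assay, > 50000 nM. Compound 3 likewise gives only a limit, > 50000 nM. Two of the three entries thus sit at the limit of > 50000 nM in this assay, at which 2 of the 3 values shown sit, and compound 1 has no value of its own to place against them.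

Compound 4 `CC(Sc1nnc(-c2ccncc2)s1)C(=O)Nc1ccc(Cl)cc1` differs from compound 1 in one place: 4-chlorophenyl in place of 4-chlorobenzyl on an amide-type nitrogen. No step between measured compounds is shown, so the size of this change in this assay cannot be read from a neighbour. Given that both measured entries rest at the limit, no step beyond the scatter is expected, in either direction. Compound 4 is expected to give about 50000 nM in this assay, within a range of 20000 nM to 100000 nM, most likely reported as a limit only.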

Compound 4, half-maximal cytotoxic concentration: > 50000 nM
Compound 4 ended at the assay's limit; the forecaster's own chance of this, stated with the estimate: 70%; the middle value lies on the limit itself.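

Within the data shown here, compound 1 carries no value in this assay, and no step from it to compound 4 can be read. Compound 4 gives only a limit of the assay, > 50000 nM. The compounds shown leave open at what concentration any of them would become cytotoxic.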